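Ethyl to benzyl on the amide-type nitrogen

A few compounds are considered here, and "the series" means these few. Any claim that something is new, unique, unknown or untested is made for them only; others in the source may bear on it.

Compound 2 `CCN(CC(=O)O)C(=O)/C(C)=C/c1ccc(C(=O)Oc2ccc(C(=N)N)cc2)cc1` stands at > 1 h in an in vitro ADME assay on the whole organism (small intestine) for pharmacokinetics, with Rattus norvegicus as the target (a higher number here means that the compound lasts longer, a lower number that the compound disappears faster), which is a limit of the assay and not a number. Compound 1 `C/C(=C\c1ccc(C(=O)Oc2ccc(C(=N)N)cc2)cc1)C(=O)N(CC(=O)O)C1CCCCC1` gives 0.817 h in this assay. Within the data shown here, the one measured step bearing on the change is an at least 1.2-fold higher number from compound 1 to compound 2 (0.08 log units; that floor lies within the scatter), with ethyl in place of cyclohexyl on an amide-type nitrogen. Compound 3 `C/C(=C\c1ccc(C(=O)Oc2ccc(C(=N)N)cc2)cc1)C(=O)N(CC(=O)O)Cc1ccccc1` differs from compound 2 by phenyl in place of methyl on a saturated chain carbon bound to an amide-type nitrogen, which reads as ethyl to benzyl. With a ring back on that nitrogen substituent, compound 1 at 0.817 h is the closest guide, so a small fall, possibly within the scatter, is expected. The expected step is an at least 1.2-fold lower number from compound 2 to compound 3 (0.09 log units; that floor lies within the scatter). Compound 3 is estimated at 0.8 h, with an expected range of 0.4 h to 1.5 h.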

Compound 3, half-life: 0.833 h
For compound 3 the middle estimate is 1.0-fold (0.02 log units) below the measured one, within the range that was stated.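

Benzyl in place of cyclohexyl on the amide-type nitrogen gives a 1.0-fold higher number from compound 1 to compound 3 (0.01 log units; within the scatter) and in this assay these two substituents cannot be told apart. Phenyl in place of methyl on the saturated chain carbon gives an at least 1.2-fold lower number from compound 2 to compound 3 (0.07 log units; that floor lies within the scatter) and that floor alone shows no real change. Compound 2 remains a limit of the assay and not a number: the limit of > 1 h in this assay, at which 1 of the 3 values shown sits.

On these data alone, how far ethyl truly stands from benzyl stays open. So does the effect of a longer chain such as phenethyl, or of an amine on that nitrogen substituent.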